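This account rests on a few compounds, and the source may have more. Where it says the series, first, only, none or still open, it means among the compounds named here.

The measured compounds:

Compound 1 `Clc1cccc(Nc2ncnc3ccc(NCc4ccc(Br)s4)cc23)c1` — 820 nM
Compound 2 `CSCCCNc1ccc2ncnc(Nc3cccc(Cl)c3)c2c1` — 3820 nM
Compound 3 `O=C(/C=C/c1cccnc1)Nc1ccc2ncnc(Nc3cccc(Cl)c3)c2c1` — 4320 nM

All three share one core and were tested in a functional assay on A549 cells (Homo sapiens) for antiproliferative activity, read by MTT assay, with a stated time of 48 h; on this read-out higher numbers stand for weaker inhibition and lower numbers for stronger inhibition. Compound 3 gives the highest of the three numbers. Its number and that of compound 2 lie within the scatter of each other, so nothing separates them; compound 1 gives a number beyond the scatter below that of compound 3. Among the measured compounds shown here, the only step between two measured compounds is a 4.7-fold higher number from compound 1 to compound 2 (0.67 log units; beyond the scatter), a change on a saturated chain carbon bound to a nitrogen on an aromatic ring.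

Compound 4 `Cc1cccc(/C=C/C(=O)Nc2ccc3ncnc(Nc4cccc(Cl)c4)c3c2)n1` differs from compound 3 in one place: 6-methylpyridin-2-yl in place of pyridin-3-yl on a double-bonded chain carbon bound to a double-bonded chain carbon. For the measured compounds named here, the single measured step sits on a different part of the molecule and so gives only a weak guide; nothing measured here shows what swapping one pyridine ring for another on the double-bonded chain carbon does. The expectation for compound 4 in this assay is therefore a number close to that of compound 3, with the step of a 1.1-fold lower number from compound 3 to compound 4 (0.03 log units; within the scatter) estimated to stay within the scatter. Compound 4 is expected to give about 4000 nM, between 1500 nM and 11000 nM.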

Compound 4, half-maximal inhibitory concentration: 2160 nM
Compound 4: the middle estimate sits 1.9-fold (0.27 log units) above what was measured; low and high end bracket the measured number.
By their numbers in this assay, from the lowest: compound 1; then compounds 4, 2 and 3 (each within the scatter of the next).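

In this assay the swap gives a 2.0-fold lower number from compound 3 to compound 4 (0.30 log units; within the scatter) and this step stays within the usual scatter, so compound 3 and compound 4 cannot be told apart. Among the compounds shown here, this is the first reading at the double-bonded chain carbon, and it shows that the ring there can go from pyridin-3-yl to 6-methylpyridin-2-yl, gaining one heavy atom, with no change that rises above the scatter. Nothing at hand explains this result.

The swap alters the way the pyridine ring is attached and adds a methyl group in a single move, so a plain pyridin-2-yl group would be needed to tell these two changes apart. Also open, as far as these compounds go, is how this carbon would respond to a group that is not a pyridine, such as a phenyl ring or a dimethylaminomethyl chain.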